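The source may hold more compounds than are shown below. What is called first, only, known or untested is meant among the compounds shown, and "the series" means these compounds.

Series notes: a shared core carrying a basic side chain and a varied aryl group, all read in a functional assay on A549 cells (Homo sapiens) for inhibition, read by MTT assay, with a stated time of 72 h; on this read-out higher numbers stand for weaker inhibition and lower numbers for stronger inhibition.

Compound 1 `COc1ccc(-n2nc(C(=O)Nc3ccc(Oc4ccnc5cc(OCCCN6CCCC6)c(OC)cc45)c(F)c3)c(C)cc2=O)cc1` gives 2770 nM in this assay. Compound 2 `COc1ccc(-n2nc(C(=O)Nc3ccc(Oc4ccnc5cc(OCCCN6CCCCC6)c(OC)cc45)c(F)c3)c(C)cc2=O)cc1` differs from compound 1 only by piperidin-1-yl in place of pyrrolidin-1-yl on a saturated chain carbon, three bonds along the chain from an oxygen on an aromatic ring; in this assay compound 2 gives 1500 nM, and the step of a 1.8-fold lower number from compound 1 to compound 2 (0.27 log units; within the scatter) is one that cannot be told apart from repeat scatter.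

Compound 3 `COc1cc2c(Oc3ccc(NC(=O)c4nn(-c5ccc(Cl)cc5)c(=O)cc4C)cc3F)ccnc2cc1OCCCN1CCCC1` differs from compound 1 by chloro in place of methoxy on an aromatic carbon. In this assay compound 3 gives 230 nM, the step being a 12-fold lower number from compound 1 to compound 3 (1.08 log units; beyond the scatter). Compound 3 holds the lowest of the three numbers, with compound 2 the nearest to it and compound 1 the furthest; both gaps lie beyond the scatter.

Compound 4 `COc1cc2c(Oc3ccc(NC(=O)c4nn(-c5ccc(Cl)cc5)c(=O)cc4C)cc3F)ccnc2cc1OCCCN1CCCCC1` is not yet measured. It differs from compound 3 by piperidin-1-yl in place of pyrrolidin-1-yl on a saturated chain carbon, three bonds along the chain from an oxygen on an aromatic ring, the same change already made from compound 1 to compound 2, with the same surroundings at the place of change; the two cores differ by chloro in place of methoxy on an aromatic carbon. Within the data shown here, only one earlier instance of this change exists, so the expectation rests on a single step. The step from compound 3 to compound 4 is expected to be about a 1.5-fold lower number from compound 3 to compound 4 (0.19 log units; within the scatter), close to the earlier one because a 1.8-fold lower number from compound 1 to compound 2 (0.27 log units; within the scatter) fell within the scatter. Compound 4 is therefore estimated at 150 nM in this assay, with a plausible range from 70 nM to 350 nM.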

Compound 4, half-maximal inhibitory concentration: 320 nM
For compound 4 the middle estimate is 2.1-fold (0.33 log units) below the measured one; measured number inside the range.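

In this assay, piperidin-1-yl in place of pyrrolidin-1-yl on the chloro-bearing core gives a 1.4-fold higher number from compound 3 to compound 4 (0.14 log units; within the scatter), so this change cannot be told apart from repeat scatter on either core, and the two steps do not differ: the same change on two cores in this assay, a 1.8-fold lower number (0.27 log units; within the scatter) from compound 1 to compound 2 and a 1.4-fold higher number (0.14 log units; within the scatter) from compound 3 to compound 4, 2.6-fold (0.41 log units) apart, within the scatter of two such steps

Chloro in place of methoxy, read with piperidin-1-yl in the side chain, gives a 4.7-fold lower number from compound 2 to compound 4 (0.67 log units; beyond the scatter), a lower number beyond the scatter like the step read with pyrrolidin-1-yl, and the two readings again do not differ: the same change on two cores in this assay, a 12-fold lower number (1.08 log units; beyond the scatter) from compound 1 to compound 3 and a 4.7-fold lower number (0.67 log units; beyond the scatter) from compound 2 to compound 4, 2.6-fold (0.41 log units) apart, within the scatter of two such steps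

Within these four compounds, each change therefore carries from one core to the other without a detectable dependence on the second place, with the aryl change accounting for the clear steps and the ring change for none; this rests on one pair of steps per change in a single assay, and it does not show that the ring change has no effect at all, nor that a small dependence between the two places is absent.

Still open, from the compounds shown here alone, is whether the same holds for morpholin-4-yl or dimethylamino in place of the saturated ring, or for a butyl chain in place of the propyl chain. Equally open, going by these compounds, is whether fluoro or trifluoromethyl in place of chloro on the aromatic carbon would extend the step seen with chloro.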